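Cyclic peptide series: side-chain swap at ring amide nitrogen

A few compounds are considered here, and "the series" means these few. Any claim that something is new, unique, unknown or untested is made for them only; others in the source may bear on it.

Compound 2 `CCCCN1C(=O)[C@@H](C)NC(=O)[C@@H]2Cc3ccc(OC)c(c3)Oc3ccc(cc3)C[C@@H](C(=O)N2C)N(C)C(=O)[C@H](C)NC(=O)[C@H](Cc2ccc(OC)cc2)N(C)C(=O)[C@@H]1C` has the lowest of the two numbers measured in a functional assay on P388 cells (Mus musculus) for cytotoxicity; a lower number here means a stronger inhibitor, a higher number a weaker inhibitor; in this assay compound 2 gives 12 nM. Going by the values given here, the only other measured member, compound 1 `COc1ccc(C[C@H]2C(=O)N[C@@H](C)C(=O)N(C)[C@H]3Cc4ccc(cc4)Oc4cc(ccc4OC)C[C@@H](C(=O)N[C@H](C)C(=O)N[C@@H](CCC(=O)O)C(=O)N2C)N(C)C3=O)cc1`, differs from it in several places and gives 219 nM in this assay; the two structures are not linked by a single change, so the pair shows only its two values.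

Compound 3 `COc1ccc(C[C@H]2C(=O)N[C@@H](C)C(=O)N(C)[C@H]3Cc4ccc(cc4)Oc4cc(ccc4OC)C[C@@H](C(=O)N[C@H](C)C(=O)N(C/C=C/c4ccccc4)[C@@H](C)C(=O)N2C)N(C)C3=O)cc1` is not yet measured. It differs from compound 2 in one place: 2-phenylethenyl in place of propyl on a saturated chain carbon bound to an amide-type nitrogen in a ring. Among the compounds with values here, no measured pair carries this kind of change, so there is no direct precedent for its size or direction. The expectation is a small step, within or close to the scatter, with a slight lean toward a higher number. For compound 3 the estimated value in this assay is 20 nM, with a range from 5 nM to 80 nM, which corresponds to an expected step of a 1.7-fold higher number from compound 2 to compound 3 (0.22 log units; within the scatter).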

Compound 3, half-maximal inhibitory concentration: 10.7 nM
Estimate against measurement, compound 3: 1.9-fold (0.27 log units) above; the range from low to high includes it.
By their numbers in this assay, from the lowest: compounds 3 and 2 (each within the scatter of the next); then compound 1.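

In this assay, going by these compounds alone, the change of propyl to 2-phenylethenyl on a saturated chain carbon bound to an amide-type nitrogen in a ring gives a 1.1-fold lower number from compound 2 to compound 3 (0.05 log units; within the scatter) and is the first single-place step. This position therefore accepts an aromatic ring and a double bond outside it with no change in cytotoxicity beyond the scatter, at least for this one pair. Nothing available on these compounds speaks to the reason for this match.

On these data alone, it remains open whether the aromatic ring or the double bond can be dropped separately, as in a saturated 3-phenylpropyl group or a plain longer alkyl chain. Also open, as far as these compounds go, is how a terminal amine or hydroxyl group on this chain would read in this assay at this position.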